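The compounds below may be only part of what the source reports. "The series", "measured", "known", "first", "only" and "open" are said of these compounds alone.

Measured compounds:

Compound 1, `C=CC(=O)Nc1cc(Nc2ncc(Cl)c(Nc3ccccc3S(=O)(=O)C(C)C)n2)c(OC)cc1N1CCN(S(C)(=O)=O)CC1`, in a functional assay on NCI-H1975 cells (Homo sapiens) for inhibition, read by CellTiter-Glo, with a stated time of 72 h (on this read-out higher numbers stand for weaker inhibition of growth and lower numbers for stronger inhibition of growth), gives 40 nM.
Compound 2, `C=CC(=O)Nc1cc(Nc2ncc(Cl)c(Nc3ccccc3S(=O)(=O)C(C)C)n2)c(OC)cc1N1CCN(C)CC1`, in this assay gives 43 nM.
Compound 3, `C=CC(=O)Nc1cc(Nc2ncc(Cl)c(Nc3ccccc3S(=O)(=O)C(C)C)n2)c(OC)cc1N1CCN(C2CCCCC2)CC1`, in this assay gives 77 nM.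

Compound 3 carries the highest number of the three, but its distance to each of the others is within the scatter, so the three cannot be ranked. Compound 4, `C=CC(=O)Nc1cc(Nc2ncc(Cl)c(Nc3ccccc3S(=O)(=O)C(C)C)n2)c(OC)cc1N1CCCCC1`, differs from compound 3 in one place: piperidin-1-yl in place of 4-cyclohexylpiperazin-1-yl on an aromatic carbon. The measured steps all change only what sits on the amine nitrogen in the ring: a 1.1-fold higher number from compound 1 to compound 2 (0.03 log units; within the scatter), a 1.9-fold higher number from compound 1 to compound 3 (0.28 log units; within the scatter), and a 1.8-fold higher number from compound 2 to compound 3 (0.25 log units; within the scatter). Within the data shown here, none of them removes that nitrogen together with its substituent, as the step to compound 4 does, so no measured step matches it directly. What the measured steps do show is that varying this part of the molecule has so far left the numbers in this assay essentially unchanged. On that basis a step within the scatter is expected, a 1.3-fold lower number from compound 3 to compound 4 (0.11 log units; within the scatter). Compound 4 is therefore estimated at 60 nM, within a range of 25 nM to 200 nM.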

Compound 4, concentration for 50% growth inhibition: 240 nM
Beside the measured number, compound 4's estimate is 4.0-fold (0.60 log units) below it, and the stated range ends below it.
By their numbers in this assay, from the lowest: compounds 1, 2 and 3 (each within the scatter of the next); then compound 4.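

Changing only what sits on the amine nitrogen in the ring had kept the numbers within the scatter, but replacing the whole group with piperidin-1-yl, which lacks that nitrogen and its substituent, does change the result in this assay. The change gives (a 3.1-fold higher number from compound 3 to compound 4 (0.49 log units; beyond the scatter)), (a 5.6-fold higher number from compound 2 to compound 4 (0.75 log units; beyond the scatter)) and (a 6.0-fold higher number from compound 1 to compound 4 (0.78 log units; beyond the scatter)), all beyond the scatter and all towards weaker inhibition of growth. At this aromatic carbon, then, methylsulfonyl, methyl and cyclohexyl on the nitrogen give numbers within the scatter of one another, while the piperidin-1-yl compound stands apart, and nothing available here explains that gap.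

These compounds do not separate the loss of the nitrogen from the loss of its substituent. Morpholin-4-yl, whose ring holds an oxygen instead of that nitrogen, and piperidin-1-yl carrying a dimethylamino group remain open comparisons.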